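Quinoline Amide Analogues Assessed for Cytotoxicity in Gastric Cells

The source may report more compounds than this note shows. Statements on the series, on what has been measured and on what is new or still open speak of the compounds shown alone.

Measured compounds:
compound 1 `COc1cc2c(Oc3ccc(NC(=O)c4cc(-c5ccc(C)cc5)nc5ccccc45)cc3F)ccnc2cc1OCCCN1CCC(C)CC1` 770 nM
compound 2 `COc1cccc(-c2cc(C(=O)Nc3ccc(Oc4ccnc5cc(OCCCN6CCC(C)CC6)c(OC)cc45)c(F)c3)c3cc(F)ccc3n2)c1` 730 nM

In a functional assay on MKN-45 cells (Homo sapiens) for cytotoxicity, read by MTT assay, with a stated time of 72 h (on this read-out lower numbers stand for stronger inhibition and higher numbers for weaker inhibition), compound 2 gives 730 nM, the lowest of the two numbers recorded. Its nearest neighbour is compound 1, which in this assay gives 770 nM, a difference that falls within the scatter of repeated measurements, so the two compounds cannot be told apart on this read-out.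

Compound 3 `COc1cc2c(Oc3ccc(NC(=O)c4cc(-c5ccc(C)cc5)nc5ccc(F)cc45)cc3F)ccnc2cc1OCCCN1CCC(C)CC1` has not yet been measured. Relative to compound 2, it carries 4-methylphenyl in place of 3-methoxyphenyl on an aromatic carbon. Among the measured compounds shown here, no pair of measured compounds differing in one place is available, so the size of this change cannot be read off directly. Since compound 1 and compound 2 sit within the scatter of each other, the expectation for compound 3 is a step of a 1.0-fold higher number from compound 2 to compound 3 (0.01 log units; within the scatter) that stays within the scatter, with no direction favoured. Compound 3 is therefore estimated at 750 nM in this assay, with a range from 350 nM to 1600 nM.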

Compound 3, half-maximal inhibitory concentration: 260 nM
The estimate for compound 3 lay 2.9-fold (0.46 log units) above the measured number; measured number outside the range, below it.
By their numbers in this assay, from the lowest: compound 3; then compounds 2 and 1 (each within the scatter of the next).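

In this assay, 4-methylphenyl in place of 3-methoxyphenyl, on the aromatic carbon next to the ring nitrogen, gives a 2.8-fold lower number from compound 2 to compound 3 (0.45 log units; beyond the scatter), which shows that the number responds to the group at this position when the fluoro is present on the core. With 4-methylphenyl kept, fluoro in place of hydrogen on an aromatic carbon gives a 3.0-fold lower number from compound 1 to compound 3 (0.47 log units; beyond the scatter), so this small replacement also moves the number beyond the scatter, which the near-identical earlier pair could not show. No measurement shown accounts for either step.

On these data alone, it remains open whether the aryl change would give a similar step without the fluoro, so the two steps cannot be treated as independent. As far as these compounds go, it is also open whether the methyl or the methoxy accounts for the aryl step, a question that 4-methoxyphenyl or 3-methylphenyl at this carbon would address.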